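This account rests on a few compounds, and the source may have more. Where it says the series, first, only, none or still open, it means among the compounds named here.

Measured so far:
- Compound 1, `CC/C(=C(/c1ccc(/C=C/C(=O)O)cc1)c1ccc2[nH]ncc2c1)c1ccccc1`: 7.2 nM
- Compound 2, `CC/C(=C(/c1ccc(/C=C/C(=O)O)cc1)c1ccc2[nH]nc(F)c2c1)c1ccccc1`: 5 nM

In a functional assay on MCF7 cells (Homo sapiens) for cytotoxicity, read by CellTiter-Glo, with a stated time of 5 days (a lower number here means a stronger inhibitor, a higher number a weaker inhibitor), compound 2 gives the lowest of the two numbers recorded, and compound 1 sits nearest to it; the two values lie within the scatter of each other, so no order between them can be claimed. The next compound, compound 3 `CC/C(=C(/c1ccc(/C=C/C(=O)O)cc1)c1ccc2[nH]nc(Cl)c2c1)c1ccccc1`, differs from compound 2 by a single exchange: chloro in place of fluoro on an aromatic carbon. For the measured compounds named here, the only measured step that bears on this position is the one a 1.4-fold lower number from compound 1 to compound 2 (0.16 log units; within the scatter), which swapped hydrogen for fluoro at the same aromatic carbon and stayed within the scatter. Nothing measured here separates chloro from fluoro, so compound 3 is expected to behave much like compound 2, with the step of no change at the digits printed from compound 2 to compound 3 (within the scatter) expected to remain inside the usual scatter. Compound 3 is therefore estimated at 5 nM in this assay, with a range from 2 nM to 12 nM.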

Compound 3, half-maximal inhibitory concentration: 284 nM
Beside the measured number, compound 3's estimate is 57-fold (1.75 log units) below it; the whole stated range lies below it.
By their numbers in this assay, from the lowest: compounds 2 and 1 (each within the scatter of the next); then compound 3.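

In this assay this aromatic carbon proves sensitive to the group it carries: putting chloro in place of fluoro gives a 57-fold higher number from compound 2 to compound 3 (1.75 log units; beyond the scatter), and putting chloro in place of hydrogen gives a 39-fold higher number from compound 1 to compound 3 (1.60 log units; beyond the scatter), so compound 3 is the weakest of the three. Hydrogen and fluoro had stayed within the scatter of each other, and that earlier pair gave no sign that a single halogen exchange at this carbon could matter so much. Nothing available here accounts for the difference between fluoro and chloro at this position.

The compounds shown leave open whether bromo, a methyl group or a nitrile on the same carbon would fall with hydrogen and fluoro or with chloro. They also leave open whether an amine or a hydroxyl group would be tolerated there.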